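From an isothiazole to a pyridine on the same core

The source may report more compounds than this note shows. Statements on the series, on what has been measured and on what is new or still open speak of the compounds shown alone.

Three compounds share one core and differ only in the aromatic group at its far end. Compound 1 `CCC(C)(C)Cc1c[nH]c(CCc2ccc(-c3cccc(C)n3)cc2)n1` carries a 6-methylpyridin-2-yl group, and in an in vitro assay on CHO cells for displacement of a labelled ligand from Bombesin receptor subtype-3 (Homo sapiens), read by scintillation counting, with a stated time of 2 h (a lower number here means a stronger inhibitor, a higher number a weaker inhibitor), compound 1 gives 6.3 nM. Compound 2 `CCC(C)(C)Cc1c[nH]c(CCc2ccc(-n3cccn3)cc2)n1` carries a 1H-pyrazol-1-yl group, and in this assay compound 2 gives 33 nM. Compound 3 `CCC(C)(C)Cc1c[nH]c(CCc2ccc(-c3cnsc3)cc2)n1` carries a 1,2-thiazol-4-yl group, and in this assay compound 3 gives 10 nM. Among these three numbers compound 3 stands second highest: a 1.6-fold higher number from compound 1 to compound 3 (0.20 log units; within the scatter), while a 3.3-fold lower number from compound 2 to compound 3 (0.52 log units; beyond the scatter).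

Compound 4 `CCC(C)(C)Cc1c[nH]c(CCc2ccc(-c3cccnc3)cc2)n1` has not been measured. It differs from compound 3 in one place: pyridin-3-yl in place of 1,2-thiazol-4-yl on an aromatic carbon. The nearest guide is the earlier exchange of a six-membered ring for a five-membered one, a 1.6-fold higher number from compound 1 to compound 3 (0.20 log units; within the scatter), which stayed within the scatter. The larger step, a 3.3-fold lower number from compound 2 to compound 3 (0.52 log units; beyond the scatter), involved a 1H-pyrazol-1-yl group, which compound 4 does not carry. The step from compound 3 to compound 4 is therefore expected to be small, with no direction beyond the scatter: a 1.3-fold lower number from compound 3 to compound 4 (0.10 log units; within the scatter). In this assay compound 4 is expected to give 8 nM, within a range from 3 nM to 25 nM.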

Compound 4, half-maximal inhibitory concentration: 7.5 nM
Compound 4: the middle estimate sits 1.1-fold (0.03 log units) above what was measured; the measured number falls inside the stated range.
By their numbers in this assay, from the lowest: compounds 1, 4 and 3 (each within the scatter of the next); then compound 2.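

In this assay the pyridin-3-yl ring of compound 4 serves about as well as the five-membered ring it replaces, with a 1.3-fold lower number from compound 3 to compound 4 (0.12 log units; within the scatter) as the step, and it also stays level with the larger ring group of compound 1, with a 1.2-fold higher number from compound 1 to compound 4 (0.08 log units; within the scatter) as the step. At this position, on an aromatic carbon para to a large group, the pyridin-3-yl, 6-methylpyridin-2-yl and 1,2-thiazol-4-yl groups therefore cannot be told apart, whether the ring is five- or six-membered and whether or not it carries a methyl group, while the 1H-pyrazol-1-yl group of compound 2 stands apart, with a 4.4-fold lower number from compound 2 to compound 4 (0.64 log units; beyond the scatter) as the step to compound 4. Nothing measured here explains why these three rings read alike or why the 1H-pyrazol-1-yl group differs from them.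

As far as these compounds go, all four groups at this position are aromatic rings, so it remains open how a non-aromatic group such as a morpholine ring, an amine or a carboxylic acid would read here. From the compounds shown here alone, it is also open whether a plain phenyl ring, with no hetero atom at all, would fall level with the pyridin-3-yl group or with the 1H-pyrazol-1-yl group.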